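Methoxy in place of hydrogen on compound 1

The source may hold more compounds than are shown below. What is called first, only, known or untested is meant among the compounds shown, and "the series" means these compounds.

In a functional assay on ZR-75-1 cells (Homo sapiens) for inhibition, read by sulforhodamine B assay (a lower number here means a stronger inhibitor of growth, a higher number a weaker inhibitor of growth), compound 1 (`c1ccc(-c2ccc(-c3ccc(-c4nc5ccccc5[nH]4)cc3)cc2)cc1`) gives 100000 nM as the highest of three numbers, beyond the scatter from both of the others. Compound 2 (`Cc1ccc2[nH]c(-c3ccc(-c4ccc(-c5ccc(N(C)C)cc5)cc4)cc3)nc2c1`) gives 7200 nM and compound 3 (`COc1cc(-c2ccc(-c3ccc(-c4nc5cc(C)ccc5[nH]4)cc3)cc2)cc(OC)c1OC`) gives 190 nM in the same read-out. Both differ from compound 1 in more than one place, so no single change has yet been measured in this series.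

Compound 4 (`COc1ccc(-c2ccc(-c3ccc(-c4nc5ccccc5[nH]4)cc3)cc2)cc1`) is the next case, with methoxy in place of hydrogen on an aromatic carbon, phenyl to 4-methoxyphenyl (methoxy in place of hydrogen on an aromatic carbon). Compound 3 also carries methoxy groups and reaches 190 nM with its further changes, so only part of its gap to compound 1 is expected to carry over. The expected step (a 17-fold lower number from compound 1 to compound 4 (1.22 log units; beyond the scatter)) runs toward a lower number in this assay and lies beyond the scatter, though the evidence for its size is indirect. For compound 4 the estimated value is 6000 nM with an expected range from 700 nM to 50000 nM in this read-out.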

Compound 4, concentration for 50% growth inhibition: 35100 nM
Compound 4: the middle estimate sits 5.9-fold (0.77 log units) below what was measured, and the stated range covers the measured number.
By their numbers in this assay, from the lowest: compound 3; then compound 2; then compound 4; then compound 1.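

In this assay, going by these compounds alone, the first single change gives a 2.8-fold lower number from compound 1 to compound 4 (0.45 log units; beyond the scatter), so methoxy in place of hydrogen on an aromatic carbon, para to a large group, lowers the number by a modest step that lies beyond the scatter. Within the data shown here, compound 2 and compound 3 each differ from compound 1 in more than one place, so only this step isolates the contribution of one group. No available data account for the size of this step.

As far as these compounds go, it remains open how a hydroxyl, a fluorine or a carboxylic acid would compare with methoxy at the same place. Also open, from the compounds shown here alone, is how much of the lower numbers of compound 2 and compound 3 comes from each of their separate differences from compound 1.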